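This account rests on a few compounds, and the source may have more. Where it says the series, first, only, none or still open, it means among the compounds named here.

In an assay on COS-7 cells for inhibition of sodium/nucleoside cotransporter 2 (Homo sapiens), read by scintillation counting (a lower number here means a stronger inhibitor, a higher number a weaker inhibitor), compound 1, whose structure is `CCOc1cc(CNc2nc3c(N)ncnc3n2[C@@H]2O[C@H](CO)[C@@H](O)[C@H]2O)ccc1-c1ccccc1`, gives 2300 nM, the second highest of the three numbers recorded so far. Compound 2, `Nc1ncnc2c1nc(NCc1ccc(-c3ccccc3)cc1O)n2[C@@H]1O[C@H](CO)[C@@H](O)[C@H]1O`, gives 1300 nM, which lies within the usual scatter of compound 1. Compound 3, `CCOc1cc(-c2ccccc2)ccc1CNc1nc2c(N)ncnc2n1[C@@H]1O[C@H](CO)[C@@H](O)[C@H]1O`, gives 5400 nM, beyond the scatter from compound 1. For the measured compounds named here, the only step between two measured compounds that differ in one place is a 4.2-fold higher number from compound 2 to compound 3 (0.62 log units; beyond the scatter).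

Compound 4, `Nc1ncnc2c1nc(NCc1ccc(-c3ccccc3)c(OCCO)c1)n2[C@@H]1O[C@H](CO)[C@@H](O)[C@H]1O`, differs from compound 1 by hydroxy in place of hydrogen on a saturated chain carbon, two bonds along the chain from an oxygen on an aromatic ring. Going by the values given here, no measured pair shows this same change, so the one measured step, which concerns an ethyl entering on an aromatic oxygen rather than a hydroxy entering on a chain carbon, bears on it only loosely. It shows that touching this part of the molecule can move the number by a modest amount, in either direction. Without a closer precedent, the most defensible expectation is a step within or near the scatter, so the step from compound 1 to compound 4 is estimated at a 1.2-fold lower number from compound 1 to compound 4 (0.06 log units; within the scatter). Compound 4 is therefore expected to give about 2000 nM in this assay, plausibly between 700 nM and 6000 nM.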

Compound 4, half-maximal inhibitory concentration: 3100 nM
Beside the measured number, compound 4's estimate is 1.6-fold (0.19 log units) below it; measured number inside the range.
By their numbers in this assay, from the lowest: compounds 2, 1, 4 and 3 (each within the scatter of the next, the first and the last beyond it).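

Turning ethoxy into 2-hydroxyethoxy brings a 1.3-fold higher number from compound 1 to compound 4 (0.13 log units; within the scatter) and so no change that can be told apart from the scatter of repeat measurements. For the compounds shown here, this is the first look at a change on the saturated chain itself, since the earlier step concerned only an ethyl entering on an aromatic oxygen, and it shows that this chain can carry a hydroxy, with its hydrogen-bond donor and acceptor, while the number stays within the scatter. No separate measurement tells what the hydroxy does at this place.

An amine or a carboxylic acid in place of this hydroxy, or a longer chain carrying it, remains an open case. One pair also cannot show whether the same change would behave alike on the ethoxy of compound 3.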